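The source may hold more compounds than are shown below. What is called first, only, known or untested is meant among the compounds shown, and "the series" means these compounds.

Compound 1 `CNC(=O)c1nc(-c2ccccc2)[nH]c1C(=O)O`: "not determined" (no result reported)
Compound 2 `CN(Cc1ccccc1)C(=O)c1nc(-c2ccccc2)[nH]c1C(=O)O`: > 200000 nM

In a functional assay on PC-3 cells (Homo sapiens) for inhibition (on this read-out lower numbers stand for stronger inhibition of growth and higher numbers for weaker inhibition of growth), compound 2 gives > 200000 nM, which is a limit of the assay and not a number. Compound 3 `O=C(O)c1[nH]c(-c2ccccc2)nc1C(=O)N(Cc1ccccc1)Cc1ccccc1` differs from compound 2 by phenyl in place of hydrogen on a saturated chain carbon bound to an amide-type nitrogen, or methyl to benzyl. Among the compounds with values here, no measured step shows what this change does in this assay. Only a small move towards stronger inhibition of growth is expected, the estimated at least 1.3-fold lower number from compound 2 to compound 3 (0.12 log units; that floor lies within the scatter). Compound 3 is expected at 150000 nM, with an estimated range from 50000 nM to 300000 nM.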

Compound 3, concentration for 50% growth inhibition: 21000 nM
Beside the measured number, compound 3's estimate is 7.1-fold (0.85 log units) above it; measured number outside the range, below it.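

In this assay, phenyl in place of hydrogen on a saturated chain carbon bound to an amide-type nitrogen, or methyl to benzyl, brings growth inhibition within the range of the assay, with an at least 9.5-fold lower number from compound 2 to compound 3 (0.97 log units; beyond the scatter). This places a change at this position beyond the scatter, and compound 3 is the only compound shown with a single number. Compound 2 stands at a limit of the assay and not at a number, so the step gives only a floor: the limit of > 200000 nM in this assay, at which 1 of the 3 values shown sits.

The compounds shown leave open whether phenyl is needed at this place. They also leave open how a longer chain or an amine there would compare with benzyl.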